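The compounds below may be only part of what the source reports. "The series", "measured", "known", "first", "only" and "open" are said of these compounds alone.

Three compounds with a shared core, carrying a nitrile and a variable group on a nitrogen attached to an aromatic carbon, have been measured in a physicochemical assay for lipophilicity, read by HPLC, at pH 7.5; a lower number here means a more polar compound, a higher number a more lipophilic compound. Compound 1 `CCOc1ccccc1-c1ccc(-c2nc3cnccc3c(NC(C(N)=O)C3CC3)c2C#N)cc1` gives 3. Compound 2 `CCOc1ccccc1-c1ccc(-c2nc3cnccc3c(N[C@H](CC(C)C)C(N)=O)c2C#N)cc1` gives 3.4, and compound 3 `CN(CC(N)=O)c1c(C#N)c(-c2ccc(Br)cc2)nc2cnccc12` gives 2.1. Compound 2 thus stands at the top of the three: compound 1 sits closest to it, and compound 3 furthest away, both beyond the scatter. Going by the values given here, the one measured step between neighbours, a number 0.40 log units higher from compound 1 to compound 2 (beyond the scatter), came with the 1-carbamoyl-3-methylbutyl group replacing a smaller group that held a three-membered ring.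

Compound 4 `CCOc1ccccc1-c1ccc(-c2nc3cnccc3c(N[C@H](CC)C(=O)NS(C)(=O)=O)c2C#N)cc1` is the next step from compound 2: a group of 10 heavy atoms (5 carbon, 1 nitrogen, 3 oxygen, 1 sulfur; no ring) in place of a group of 8 heavy atoms (6 carbon, 1 nitrogen, 1 oxygen; no ring), on a nitrogen on an aromatic ring. Among the compounds with values here, no measured pair mirrors this exchange; the step from compound 1 to compound 2 only added carbon, whereas here carbon is lost and oxygen and sulfur enter, so that step offers no direct guide. On the counts alone, a downward move in this assay is expected for compound 4, estimated at 1.4, within 0.4 to 2.6, which would mean a number 2.00 log units lower from compound 2 to compound 4 (beyond the scatter).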

Compound 4, distribution coefficient: 2.2
For compound 4 the middle estimate is 0.80 log units below the measured one, and the stated range covers the measured number.
By their numbers in this assay, from the lowest: compounds 3 and 4 (each within the scatter of the next); then compound 1; then compound 2.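

At this position, on a nitrogen on an aromatic ring, the earlier step in this assay went upward, whereas the new group brings a number 1.20 log units lower from compound 2 to compound 4 (beyond the scatter) and also a number 0.80 log units lower from compound 1 to compound 4 (beyond the scatter). The number here can therefore move in either direction, and the count of heavy atoms alone does not set which: the entering group is larger than the groups it replaces in both steps, yet compound 4 reads lower, while the larger group of compound 2 reads higher than that of compound 1. Nothing measured here gives a reason for the fall.

Going by these compounds, compound 4 differs from compound 2 in both its carbon chain and the group on its carbonyl, so the share of each in the step stays open. A 1-carbamoylpropyl group at this nitrogen, or a carboxylic acid on the same chain, would help to separate the two.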